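Trimming a Side Chain: Sec-Butyl to Isopropyl

The source may hold more compounds than are shown below. What is called first, only, known or untested is meant among the compounds shown, and "the series" means these compounds.

Of the compounds shown here, two have been measured in a functional assay on the whole organism (Ear, strain ICR) for inhibition, with Mus musculus as the target, with stated times of 30 min and 2 h, at a dose of 10 umol/kg by the oral route; a higher number here means more inhibition at the dose given (going by the name of the read-out), a lower number less inhibition. Compound 1 `C[C@H](NCCC1OCC(C)(C)CO1)C(=O)N[C@H]1[C@@H](OCc2ccccc2)O[C@H](COCc2ccccc2)[C@@H](OCc2ccccc2)[C@@H]1OCc1ccccc1` gives 90.3%. Compound 2 `CC[C@H](C)[C@H](NCCC1OCC(C)(C)CO1)C(=O)N[C@H]1C(O)O[C@H](CO)[C@@H](O)[C@@H]1O` gives 88.7%. The two values differ by only a small amount, so compound 2 stands alongside compound 1 within the usual scatter, and the inhibition in this assay is level between the pair. Compound 3 `CC(C)[C@H](NCCC1OCC(C)(C)CO1)C(=O)N[C@H]1C(O)O[C@H](CO)[C@@H](O)[C@@H]1O` has not yet been measured in this assay. It differs from compound 2 in one place: hydrogen in place of methyl on a saturated chain carbon, three bonds along the chain from an amine nitrogen and a carbonyl carbon. Among the measured compounds shown here, no step between measured compounds of this kind is available to guide the expectation, so the guess rests on the two values alone, which both lie high. The step from compound 2 to compound 3 is expected to be a number 1.7 percentage points lower from compound 2 to compound 3 (within the scatter), that is, no change beyond the scatter in either direction. Compound 3 is therefore estimated to give 87% in this assay, with a range from 72% to 95%.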

Compound 3, a percentage reported as inhibition, in the whole organism at one dose (the size of the read-out at that dose, not a potency): 85.1%
For compound 3 the middle estimate is 1.9 percentage points above the measured one, and the stated range covers the measured number.
By their numbers in this assay, from the lowest: compounds 3, 2 and 1 (each within the scatter of the next).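

In this assay the change from sec-butyl to isopropyl gives a number 3.6 percentage points lower from compound 2 to compound 3 (within the scatter) and so stays within the scatter. Among the compounds shown here, this is the first direct look at this position, on a saturated chain carbon, three bonds along the chain from an amine nitrogen and a carbonyl carbon. It shows that losing this one methyl leaves the inhibition at the dose given level. No supporting measurement bears on why the read-out holds steady here.

From the compounds shown here alone, what would happen with a larger group in place of the isopropyl, such as a longer chain like n-hexyl or a cyclohexyl ring, remains open, as does the effect of a plain hydrogen in place of the whole side chain. The read-out also comes from a single dose and is not a potency, so a real difference between compound 2 and compound 3 at other doses cannot be ruled out.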